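The source may report more compounds than this note shows. Statements on the series, on what has been measured and on what is new or still open speak of the compounds shown alone.

Series notes. In a functional assay for antagonist activity at 5-hydroxytryptamine receptor 4 (Cavia porcellus) (a lower number here means a less potent compound, a higher number a more potent compound, by a factor of ten per unit of this negative logarithm), compound 1 `CC(C)n1c(=O)n(C(=O)NCCN2CCN(C)CC2)c2cc(F)ccc21` gives 6.88. Compound 2 `CN1CCN(CCNC(=O)n2c(=O)[nH]c3ccccc32)CC1` is recorded in this assay only as a limit of the assay, < 6, so among the numbers shown compound 2 stands at the bottom; the limit of < 6 in this assay, at which 1 of the 2 values shown sits, marks where it sits. Compound 3 `CN1CCN(CCNC(=O)n2c(=O)n(Cc3ccccc3)c3ccccc32)CC1` has not yet been measured in this assay. The change from compound 2 to compound 3 is benzyl in place of hydrogen on an aromatic nitrogen. Compound 1 also carries a group on that aromatic nitrogen and returns a number rather than a limit, whereas compound 2 with hydrogen there reaches only the limit. On that basis compound 3 is expected to gain in this assay, and the expected step of a number at least 0.80 log units higher from compound 2 to compound 3 (beyond the scatter) is counted from a limit, so its true size is uncertain. The estimate for compound 3 in this assay is 6.8, with a range from 6 to 7.6.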

Compound 3, negative logarithm of the antagonist equilibrium constant: < 6
Compound 3 was reported as a limit; the forecaster's own chance of this, stated with the estimate: 20%; middle value at least 0.80 log units from the limit.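

In this assay, compound 2 and compound 3 both stand at a limit of the assay, so no step can be read between them: the limit of < 6 in this assay, at which 2 of the 3 values shown sit.

The compounds shown leave open whether benzyl in place of hydrogen on an aromatic nitrogen changes the antagonist potency at all, and in which direction.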